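The compounds below may be only part of what the source reports. "The series", "measured", "known", "first", "only" and "open" are said of these compounds alone.

Among the compounds with values here, in a functional assay (aorta) with Rattus norvegicus as the target, with a stated time of 90 min, at 37 degrees C (a higher number here means that more compound is needed for the effect, a lower number that less compound is needed), two compounds have values so far. Compound 1 (`CC(C)NC1=NS(=O)(=O)c2cc(Br)c(Cl)cc2N1`) gives 5600 nM, and compound 2 (`CCCNC1=NS(=O)(=O)c2cc(F)c(Cl)cc2N1`) gives 45300 nM. Compound 2 thus holds the higher number of the two, and the gap lies beyond the scatter.

The next compound, compound 3 (`CC(C)NC1=NS(=O)(=O)c2cc(F)c(Cl)cc2N1`), has isopropyl in place of propyl on an amine nitrogen. Within the data shown here, no measured pair differs in one place only, so the effect of this change has not been measured directly.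

Among the measured compounds shown here, the only pointer is compound 1 at 5600 nM, which carries the same isopropyl as compound 3 but also differs from it elsewhere on the shared core. That pointer is weak, and it suggests only a direction: a lower number, with the change perhaps modest enough to stay close to the scatter. The expected change is a 2.5-fold lower number from compound 2 to compound 3 (0.40 log units; beyond the scatter) in this assay. For compound 3 the estimated value is 18000 nM, with an expected range of 6000 nM to 50000 nM.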

Compound 3, half-maximal effective concentration: 41500 nM
Compound 3: middle estimate off by 2.3-fold (0.36 log units), on the low side; low and high end bracket the measured number.
By their numbers in this assay, from the lowest: compound 1; then compounds 3 and 2 (each within the scatter of the next).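

In this assay, the amine nitrogen now has its first direct reading: a 1.1-fold lower number from compound 2 to compound 3 (0.04 log units; within the scatter), so propyl and isopropyl cannot be told apart at this place. The aromatic carbon also has its first direct reading, and fluoro in place of bromo gives a 7.4-fold higher number from compound 1 to compound 3 (0.87 log units; beyond the scatter); of the two single changes read so far, only this one lies beyond the scatter. Nothing at hand gives a reason for either result.

On these data alone, it remains open whether the step between fluoro and bromo keeps its size with propyl on the amine nitrogen, since both steps rest on compound 3 alone. Also open, as far as these compounds go, is how the series responds to a different group on the aromatic carbon, such as iodo or nitrile, or to a longer chain or cyclopropyl on the amine nitrogen.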